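A few compounds are considered here, and "the series" means these few. Any claim that something is new, unique, unknown or untested is made for them only; others in the source may bear on it.

In a functional assay on A549 cells (Homo sapiens) for antiproliferative activity, read by MTT assay, with a stated time of 72 h (on this read-out higher numbers stand for weaker inhibition and lower numbers for stronger inhibition), three compounds have been measured so far. Compound 1 `C/C=C/C(=O)Nc1cc2c(N3CCCc4ccccc43)ncnc2cc1OC` gives 8190 nM. Compound 2 `COc1cc2ncnc(N3CCCc4ccccc43)c2cc1NC(=O)/C=C/C(C)C`, which carries an isopropyl in place of methyl on a double-bonded chain carbon bound to a double-bonded chain carbon, gives 3450 nM, a step of a 2.4-fold lower number from compound 1 to compound 2 (0.38 log units; beyond the scatter). Compound 3 `COc1cc2ncnc(N3CCc4ccccc43)c2cc1NC(=O)/C=C/CN1CCCC1` gives 1210 nM, the lowest of the three numbers and thus the strongest inhibition seen here. Compound 4 `COc1cc2ncnc(N3CCCc4ccccc43)c2cc1NC(=O)/C=C/CN1CCCC1` has not been measured. It differs from compound 3 in one place: 1,2,3,4-tetrahydroquinolin-1-yl in place of 2,3-dihydro-1H-indol-1-yl on an aromatic carbon. Among the compounds with values here, no measured step bears directly on this change; the one step that has been measured, from compound 1 to compound 2, concerns the chain end and not the ring attached on an aromatic carbon. Compounds 1 and 2 both carry the 1,2,3,4-tetrahydroquinolin-1-yl group and give higher numbers than compound 3, but they also differ from it in the chain, so what the ring change alone does is not known. The expected step is therefore small, a 1.2-fold higher number from compound 3 to compound 4 (0.06 log units; within the scatter), and compound 4 is estimated at 1400 nM, within the range 450 nM to 4500 nM.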

Compound 4, half-maximal inhibitory concentration: 2230 nM
Compound 4: middle estimate off by 1.6-fold (0.20 log units), on the low side, and the stated range covers the measured number.
By their numbers in this assay, from the lowest: compounds 3, 4 and 2 (each within the scatter of the next, the first and the last beyond it); then compound 1.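

In this assay, the six-membered 1,2,3,4-tetrahydroquinolin-1-yl in place of the five-membered 2,3-dihydro-1H-indol-1-yl gives a 1.8-fold higher number from compound 3 to compound 4 (0.27 log units; within the scatter) and so, with the chain held the same, this ring change cannot be told apart from repeat-measurement noise. On the chain, pyrrolidin-1-yl in place of hydrogen gives a 3.7-fold lower number from compound 1 to compound 4 (0.56 log units; beyond the scatter) while (pyrrolidin-1-yl)methyl in place of isopropyl gives a 1.5-fold lower number from compound 2 to compound 4 (0.19 log units; within the scatter) and so, on the tetrahydroquinoline compounds, the pyrrolidine chain end cannot be separated from isopropyl, though both read lower than the methyl end of compound 1. Nothing measured here accounts for these steps.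

Whether the ring change reads the same with a different chain end remains open, since only one such pair is shown. Also open, going by these compounds, is how a dimethylamino or morpholin-4-yl group would compare with pyrrolidin-1-yl on this chain.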